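A few compounds are considered here, and "the series" means these few. Any claim that something is new, unique, unknown or untested is made for them only; others in the source may bear on it.

Of the compounds shown here, three sharing one core have so far been tested in a functional assay on RD cells (Homo sapiens) for inhibition, read by luminescence and ATP content, with a stated time of 72 h (on this read-out lower numbers stand for higher toxicity in this test and higher numbers for lower toxicity in this test), and none of them gives a number. Compound 1 `Cc1nc(-c2cnc3ccc(-c4ccc(N)cc4)cc3c2)no1` gives > 2500 nM, which is a limit of the assay. Compound 2 `CCCc1nc(-c2cnc3ccc(-c4ccc(N)cc4)cc3c2)no1` gives > 800 nM, which is also a limit. Compound 3 `CC(C)c1nc(-c2cnc3ccc(-c4ccc(N)cc4)cc3c2)no1` gives > 800 nM, again a limit, so its place among the others cannot be ranked.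

Compound 4 `CC(C)(C)c1nc(-c2cnc3ccc(-c4ccc(N)cc4)cc3c2)no1` is reached from compound 3 by one small change: methyl in place of hydrogen on a saturated chain carbon bound to an aromatic carbon and two saturated chain carbons. This puts methyl in place of hydrogen on a saturated chain carbon bound to an aromatic carbon and two saturated chain carbons, turning isopropyl to tert-butyl.

The nearest measured changes alter the same group, but they give no size: a step that the two limits leave unreadable from compound 1 to compound 2, a step that the two limits leave unreadable from compound 1 to compound 3 and a step that the two limits leave unreadable from compound 2 to compound 3. No measured step beyond the scatter therefore exists to carry over, and all that can be drawn on is that compound 3, like its two relatives, reached only a limit at > 800 nM. No step beyond the scatter is expected in this assay, and the estimated change is a step that the limit leaves unreadable from compound 3 to compound 4. A limit rather than a number is the likeliest report. For compound 4 the expected value is 1500 nM, with an estimated range from 600 nM to 5000 nM.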

Compound 4, half-maximal cytotoxic concentration: > 7400 nM
Compound 4: a limit, no number (the forecaster's own chance of this, stated with the estimate: 75%); at least 4.9-fold (0.69 log units) between middle value and limit.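

Compound 4 gives [ > 7400 nM ], which is a limit and not a number. Compound 1, compound 2 and compound 3 also gave only limits, and none of the steps to compound 4 can be read. The compounds shown leave open whether changing the group from methyl to tert-butyl alters the half-maximal cytotoxic concentration at all.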